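The source may hold more compounds than are shown below. What is called first, only, known or untested is meant among the compounds shown, and "the series" means these compounds.

Compound 1 `C=CCOc1cc(OC)c(C(=O)/C=C/C=C/c2ccccc2)c(OCC=C)c1` carries a 2-phenylethenyl group on a double-bonded chain carbon bound to a double-bonded chain carbon, attached to the shared core. In an ADME assay on Vero cells (Chlorocebus sabaeus) for cytotoxicity, read by MTT assay (on this read-out lower numbers stand for stronger inhibition and higher numbers for weaker inhibition), compound 1 is reported as "not determined" (no result reported), so it cannot be placed on that scale; where it stands must be inferred from its neighbours. Two related compounds were measured. Compound 2 `C=CCOc1cc(OC)c(C(=O)/C=C/c2ccccc2)c(OCC=C)c1` gives 17100 nM in this assay. Compound 3 `C=CCOc1cc(OC)c(C(=O)/C=C/c2ccccc2F)c(OCC=C)c1` gives 16300 nM in this assay. Going by the values given here, the single measured change between them is a 1.0-fold lower number from compound 2 to compound 3 (0.02 log units; within the scatter), a step within the scatter, so the fluoro substitution left the number where it stood.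

Compound 4 `C=CCOc1cc(OC)c(C(=O)/C=C/c2ccco2)c(OCC=C)c1` differs from compound 1 by furan-2-yl in place of 2-phenylethenyl on a double-bonded chain carbon bound to a double-bonded chain carbon. Among the compounds with values here, no measured step exchanges one aromatic ring for a ring of another kind, so the step of a 1.0-fold lower number from compound 2 to compound 3 (0.02 log units; within the scatter) bears on the change only indirectly: it shows that altering the aromatic ring did not move the number in this assay beyond the scatter. On that basis no step beyond the scatter is expected in either direction. Because compound 2 gives 17100 nM and compound 3 gives 16300 nM, compound 4 is expected to land near them. Compound 4 is therefore estimated to give about 16000 nM in this assay, within a range from 7000 nM to 36000 nM.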

Compound 4, half-maximal inhibitory concentration: 191000 nM
Beside the measured number, compound 4's estimate is 12-fold (1.08 log units) below it, and the stated range ends below it.
By their numbers in this assay, from the lowest: compounds 3 and 2 (each within the scatter of the next); then compound 4.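

At this position, on a double-bonded chain carbon bound to a double-bonded chain carbon, the identity of the aromatic ring matters in this assay: furan-2-yl in place of 2-fluorophenyl gives a 12-fold higher number from compound 3 to compound 4 (1.07 log units; beyond the scatter), and furan-2-yl in place of phenyl gives an 11-fold higher number from compound 2 to compound 4 (1.05 log units; beyond the scatter). The earlier fluoro exchange had shown only that this one substitution on the phenyl ring left the number within the scatter, whereas exchanging the whole ring moves it by a large step towards weaker inhibition, whichever of the two phenyl compounds is the starting point. Nothing available here accounts for the size of this step.

The standing of the 2-phenylethenyl group of compound 1 remains open, as the compounds shown give no number for it on this scale. Also open, from the compounds shown here alone, is whether the step follows the five-membered ring or its oxygen, a question on which a thiophen-2-yl group or a pyridine ring at the same place would bear.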